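Moving the halogen on the ester-bearing ring of compound 1

The source may report more compounds than this note shows. Statements on the series, on what has been measured and on what is new or still open speak of the compounds shown alone.

Compound 1 `COC(=O)c1cc(Cl)ccc1OC(=O)COc1cc(O)c2c(=O)cc(-c3ccccc3)oc2c1` gives the lowest number of the three measured compounds in a functional assay on cells (T-cell, Mus musculus, strain BALB/c) for inhibition, read by MTT assay, with a stated time of 72 h (on this read-out higher numbers stand for weaker inhibition and lower numbers for stronger inhibition), at 3740 nM. Compound 3 `COC(=O)c1ccc(C)cc1OC(=O)COc1cc(O)c2c(=O)cc(-c3ccccc3)oc2c1` gives 31100 nM, and compound 2 `COC(=O)c1c(Cl)cc(Cl)cc1OC(=O)COc1cc(O)c2c(=O)cc(-c3ccccc3)oc2c1` gives 43600 nM. Compound 4 `COC(=O)c1c(Br)cccc1OC(=O)COc1cc(O)c2c(=O)cc(-c3ccccc3)oc2c1` differs from compound 1 in one place: a group of 11 heavy atoms (8 carbon, 2 oxygen, 1 bromine; one six-membered aromatic ring of carbon only) in place of a group of 11 heavy atoms (8 carbon, 2 oxygen, 1 chlorine; one six-membered aromatic ring of carbon only), on an oxygen next to a carbonyl group. Among the compounds with values here, the only measured step touching this part of the molecule is an 8.3-fold higher number from compound 1 to compound 3 (0.92 log units; beyond the scatter), where the 4-chloro-2-(methoxycarbonyl)phenyl group was also replaced; compound 2 likewise shows a higher number than compound 1. Both changes to this group weakened inhibition, so a weakening step a 3.2-fold higher number from compound 1 to compound 4 (0.51 log units; beyond the scatter) is expected here too, though its size is uncertain. Compound 4 is therefore estimated at 12000 nM, within a range from 3000 nM to 48000 nM in this assay.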

Compound 4, half-maximal inhibitory concentration: 41700 nM
Compound 4: the middle estimate sits 3.5-fold (0.54 log units) below what was measured, within the range that was stated.
By their numbers in this assay, from the lowest: compound 1; then compounds 3, 4 and 2 (each within the scatter of the next).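

Replacing the 4-chloro-2-(methoxycarbonyl)phenyl group, on an oxygen next to a carbonyl group, with the bromine-bearing ring gives an 11-fold higher number from compound 1 to compound 4 (1.05 log units; beyond the scatter) in this assay, so carrying a halogen on this ring does not by itself keep the low number of compound 1. The bromine-bearing ring also cannot be told apart from the methyl-bearing ring, with a 1.3-fold higher number from compound 3 to compound 4 (0.13 log units; within the scatter). Nothing available explains why compound 1 stands apart.

Going by these compounds, whether its low number depends on chlorine itself or on the halogen's place on the ring stays open. On these data alone, how a ring carrying fluorine or a methoxy group would read is also open.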